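The compounds below may be only part of what the source reports. "The series", "measured", "known", "first", "only" and "open" are said of these compounds alone.

Compound 1 `N=C(N)c1ccc2[nH]c(-c3ccc4nc(-c5ccc(F)cc5)[nH]c4c3)nc2c1` gives 2.48 ug/mL
Compound 2 `CC(C)(C)c1ccc(-c2nc3ccc(-c4nc5cc(C(=N)N)ccc5[nH]4)cc3[nH]2)cc1` gives 13 ug/mL
Compound 3 `N=C(N)c1ccc2[nH]c(-c3ccc4nc(-c5ccc(Oc6ccc(Cl)cc6)cc5)[nH]c4c3)nc2c1` gives 46 ug/mL

In an ADME assay on L6 cells (Rattus norvegicus) for cytotoxicity, read by resazurin assay (a lower number here means a stronger inhibitor, a higher number a weaker inhibitor), compound 3 stands highest of the three, at 46 ug/mL in this series. Compound 4 `COc1ccc(Oc2ccc(-c3nc4ccc(-c5nc6cc(C(=N)N)ccc6[nH]5)cc4[nH]3)cc2)cc1OC` is the next to consider, and 3,4-dimethoxyphenyl in place of 4-chlorophenyl on an oxygen on an aromatic ring sets out how it differs, with 3,4-dimethoxyphenyl in place of 4-chlorophenyl on an oxygen on an aromatic ring. Among the compounds with values here, three measured steps bear on this only indirectly. They are the modest 5.2-fold higher number from compound 1 to compound 2 (0.72 log units; beyond the scatter) and the large 19-fold higher number from compound 1 to compound 3 (1.27 log units; beyond the scatter) and the modest 3.5-fold higher number from compound 2 to compound 3 (0.55 log units; beyond the scatter) and each replaces the whole group on an aromatic carbon. None alters the ring on the oxygen, so a step within the scatter is expected in this assay. The expectation starts from compound 3 at 46 ug/mL with wide uncertainty. The estimated change is a 1.5-fold lower number from compound 3 to compound 4 (0.19 log units; within the scatter) and it leans slightly downward. For compound 4 the estimated value is 30 ug/mL within an expected range of 10 ug/mL to 80 ug/mL in this assay.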

Compound 4, half-maximal inhibitory concentration: 29.4 ug/mL
Compound 4: middle estimate off by 1.0-fold (0.01 log units), on the high side; measured number inside the range.
By their numbers in this assay, from the lowest: compound 1; then compound 2; then compounds 4 and 3 (each within the scatter of the next).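

In this assay, within the data shown here, the earlier steps each replaced the whole group on an aromatic carbon, whereas exchanging only the ring on the oxygen, 3,4-dimethoxyphenyl in place of 4-chlorophenyl, gives a 1.6-fold lower number from compound 3 to compound 4 (0.19 log units; within the scatter) and so no step beyond the scatter. The 3,4-dimethoxyphenoxy group still stands apart from tert-butyl, with a 2.3-fold higher number from compound 2 to compound 4 (0.35 log units; beyond the scatter), and from fluoro, with a 12-fold higher number from compound 1 to compound 4 (1.07 log units; beyond the scatter), as 4-chlorophenoxy did. No measurement here explains these steps. On these data alone, it remains open whether an amine or a carboxylic acid on that ring, or a longer chain on the oxygen in place of the ring, would also stay within the scatter.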